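Series notes: aryl imines on a shared core, cytotoxicity

A few compounds are considered here, and "the series" means these few. Any claim that something is new, unique, unknown or untested is made for them only; others in the source may bear on it.

Measured so far, in a functional assay on HT-29 cells (Homo sapiens) for cytotoxicity, read by MTT assay, with a stated time of 72 h; on this read-out lower numbers stand for stronger inhibition and higher numbers for weaker inhibition:
- compound 1 `CCOc1cccc(/C=N/c2c(C)n(C)n(-c3ccccc3)c2=O)c1` gives 295000000 nM
- compound 2 `Cc1c(/N=C/c2cccc(O)c2)c(=O)n(-c2ccccc2)n1C` gives 166000000 nM
- compound 3 `COc1cccc(/C=N/c2c(C)n(C)n(-c3ccccc3)c2=O)c1` gives 155000000 nM

Compound 3 carries the lowest of the three numbers, yet every gap to it falls inside the usual scatter: a 1.1-fold lower number from compound 2 to compound 3 (0.03 log units; within the scatter) is negligible, and a 1.9-fold lower number from compound 1 to compound 3 (0.28 log units; within the scatter) is also within scatter, as is a 1.8-fold lower number from compound 1 to compound 2 (0.25 log units; within the scatter). None of the three compounds can be called the most or least potent on these data; all three sit at very weak inhibition in this assay.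

Compound 4 `Cc1c(/N=C/c2cccc([N+](=O)[O-])c2)c(=O)n(-c2ccccc2)n1C` is not yet measured. Its change from compound 3 is nitro in place of methoxy on an aromatic carbon. Going by the values given here, no measured step replaces the methoxy with a group of another kind; the three known steps only swap hydrogen, methyl and ethyl on the same ring oxygen, and each of them stayed within the scatter. There is therefore no basis in the series for expecting a step beyond the scatter, in either direction, and compound 4 is expected to remain in the same weak region as compound 3, with a 1.0-fold lower number from compound 3 to compound 4 (0.01 log units; within the scatter) as the expected step. For compound 4 the estimate in this assay is 150000000 nM, in a range from 50000000 nM to 450000000 nM.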

Compound 4, half-maximal inhibitory concentration: 741000000 nM
Compound 4: middle estimate off by 4.9-fold (0.69 log units), on the low side; measured number above the stated range.
By their numbers in this assay, from the lowest: compounds 3, 2 and 1 (each within the scatter of the next); then compound 4.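

On the aromatic carbon meta to a large group, the series now shows a step beyond the scatter in this assay: nitro in place of methoxy (a 4.8-fold higher number from compound 3 to compound 4 (0.68 log units; beyond the scatter)), nitro in place of hydroxy (a 4.5-fold higher number from compound 2 to compound 4 (0.65 log units; beyond the scatter)) and nitro in place of ethoxy (a 2.5-fold higher number from compound 1 to compound 4 (0.40 log units; beyond the scatter)) all go towards weaker inhibition. The earlier swaps of hydrogen, methyl and ethyl on the ring oxygen left this position looking insensitive, but exchanging the whole group shows that the read-out does respond to what sits there, and compound 4 is the weakest of the four, although all four remain in a very weak region. No supporting measurement bears on why nitro gives this shift.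

Going by these compounds, whether the shift is particular to nitro remains open, since an amine, a nitrile or a carboxylic acid on the same aromatic carbon would show if other groups that are not bound through oxygen behave alike. Also open, on these data alone, is how a plain hydrogen or a halogen such as chlorine at this place compares with the hydroxy, methoxy and ethoxy compounds, which stay within the scatter of one another.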